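Amide nitrogen substituent swap in an aryl-amide series

The source may report more compounds than this note shows. Statements on the series, on what has been measured and on what is new or still open speak of the compounds shown alone.

Three compounds of the series have been run in a functional assay on NIH3T3 cells (Mus musculus) (on this read-out lower numbers stand for an effect already at smaller amounts and higher numbers for an effect only at larger amounts of compound), so far. Compound 1 `N#Cc1ccc(Cn2cncc2CNc2ccc(C(=O)Nc3cccc([N+](=O)[O-])c3)c(-c3ccccc3)c2)cc1` gives > 10 uM in this assay, which is a limit of the assay and not a number. Compound 2 `COC(=O)[C@H](CCSC)NC(=O)c1ccc(NCc2cncn2Cc2ccccc2C)cc1-c1ccccc1` also gives > 10 uM, a limit. Compound 3 `CSCC[C@H](NC(=O)c1ccc(NCc2cncn2Cc2ccccc2Cl)cc1-c1ccccc1)C(=O)O` likewise gives > 10 uM, again a limit. The whole picture of the series is thus (the limit of > 10 uM in this assay, at which 3 of the 3 values shown sit), so compound 1 cannot be placed relative to the other two beyond noting that all three values sit at the same limit.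

Compound 4 `N#CCNC(=O)c1ccc(NCc2cncn2Cc2ccc(C#N)cc2)cc1-c1ccccc1` has not yet been measured in this assay. It differs from compound 1 by cyanomethyl in place of 3-nitrophenyl on an amide-type nitrogen. Among the measured compounds shown here, no measured pair shows what a change at this position does, so there is no measured step to lean on. The expectation is therefore a step that the limit leaves unreadable from compound 1 to compound 4 that stays within the scatter and leaves compound 4 at the limit as well. Compound 4 is estimated at 20 uM, with a range from 5 uM to 80 uM.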

Compound 4, concentration for half-maximal effect: > 10 uM
Compound 4 was reported as a limit; the forecaster's own chance of this, stated with the estimate: 75%; the middle value lies beyond the limit too.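

No step can be read from compound 1 to compound 4, as both values are limits of the assay, and the series gives no comparison: the limit of > 10 uM in this assay, at which 4 of the 4 values shown sit.

The compounds shown leave open what cyanomethyl in place of 3-nitrophenyl on an amide-type nitrogen does in this assay, and which structural features would give a readable value there.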